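Compound 2 Without Its (1-Bromoethenyl)carbonyl Group

This account rests on a few compounds, and the source may have more. Where it says the series, first, only, none or still open, it means among the compounds named here.

Three measured compounds share one core and differ only in the group attached to one aromatic carbon of that core. Compound 1 `C=C(Br)C(=O)Nc1cccc(-c2cn3nc(-c4ccc(OCC)cc4)sc3n2)c1` carries a 4-ethoxyphenyl there, and in a functional assay on L1210 cells (Mus musculus) for inhibition, read by cell counting, with a stated time of 2 days (on this read-out higher numbers stand for weaker inhibition and lower numbers for stronger inhibition), compound 1 gives 790 nM. Compound 2 `C=C(Br)C(=O)Nc1cccc(-c2cn3nc(CCc4ccccc4)sc3n2)c1` carries a phenethyl, and compound 2 gives 2200 nM. Compound 3 `C=C(Br)C(=O)Nc1cccc(-c2cn3nc(-c4cccc(OC)c4)sc3n2)c1` carries a 3-methoxyphenyl, and compound 3 gives 580 nM. Compound 2 stands highest of the three numbers: a 2.8-fold higher number from compound 1 to compound 2 (0.44 log units; beyond the scatter), and a 3.8-fold lower number from compound 2 to compound 3 (0.58 log units; beyond the scatter), whereas a 1.4-fold lower number from compound 1 to compound 3 (0.13 log units; within the scatter).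

Compound 4 `Nc1cccc(-c2cn3nc(CCc4ccccc4)sc3n2)c1` is compound 2 with a single change: hydrogen in place of (1-bromoethenyl)carbonyl on a nitrogen on an aromatic ring. Among the compounds with values here, none of the three measured steps bears on this change; every one of them swaps the group on the aromatic carbon and leaves the (1-bromoethenyl)carbonyl untouched, so no measured step gives the size of this one. Within the data shown here, the group that leaves is the only part of compound 2 with double bonds outside aromatic rings, and its removal is a larger structural change than any of the measured swaps, so a wide range is appropriate. The number for compound 4 in this assay is expected to be 15000 nM, within 3000 nM to 80000 nM. That estimate means a 6.8-fold higher number from compound 2 to compound 4 (0.83 log units; beyond the scatter), an expected loss of inhibition.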

Compound 4, half-maximal inhibitory concentration: 31000 nM
Estimate against measurement, compound 4: 2.1-fold (0.32 log units) below, within the range that was stated.
By their numbers in this assay, from the lowest: compounds 3 and 1 (each within the scatter of the next); then compound 2; then compound 4.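

In this assay, going from the (1-bromoethenyl)carbonyl on the nitrogen to a bare amino group moves the number much further (a 14-fold higher number from compound 2 to compound 4 (1.15 log units; beyond the scatter)) than the largest swap on the aromatic carbon does (a 3.8-fold lower number from compound 2 to compound 3 (0.58 log units; beyond the scatter)). The earlier compounds shown here all carried this group unchanged, so they could say nothing about it; this step shows that, with phenethyl on the aromatic carbon, most of the inhibition seen with compound 2 depends on the group on the nitrogen. Nothing available here explains why the loss is this large.

The compounds shown give only the two ends of this change, so it remains open which part of the group matters: an acetyl or a propenoyl on the same nitrogen would separate the contribution of the bromine and the carbon-carbon double bond from that of the amide carbonyl. Within the data shown here, it is also open whether a loss of this size would hold with 3-methoxyphenyl or 4-ethoxyphenyl on the aromatic carbon, since the only free amino compound here carries phenethyl.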